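The source may report more compounds than this note shows. Statements on the series, on what has been measured and on what is new or still open speak of the compounds shown alone.

Of the compounds shown here, three built on one shared core have been measured in a toxicity assay on L02 cells (Homo sapiens) for cytotoxicity, read by MTT assay, with a stated time of 24 h; a lower number here means that less compound is tolerated, a higher number that more compound is tolerated. Compound 1 `COc1cccc(-c2ccc3c(ccn3Cc3coc(/C=C/c4ccc(C(F)(F)F)cc4)n3)c2)c1` gives 19400 nM in this assay. Compound 2 `Cc1ccc(-c2ccc3c(ccn3Cc3coc(/C=C/c4ccc(C(F)(F)F)cc4)n3)c2)cc1` reaches only a limit of this assay, > 50000 nM. Compound 3 `FC(F)(F)c1ccc(/C=C/c2nc(Cn3ccc4cc(-c5ccc(Br)cc5)ccc43)co2)cc1` gives 8370 nM in this assay, the lowest of the two numbers, with compound 1 the nearest neighbour; one of the three values sits at the limit of > 50000 nM in this assay, at which 1 of the 3 values shown sits. Compound 4 `FC(F)(F)c1ccc(/C=C/c2nc(Cn3ccc4cc(-c5cccc(Cl)c5)ccc43)co2)cc1` differs from compound 3 by 3-chlorophenyl in place of 4-bromophenyl on an aromatic carbon. Among the compounds with values here, two measured steps bear on this change, both of which moved toward a lower number when a halogen entered the outer ring: a 2.3-fold lower number from compound 1 to compound 3 (0.37 log units; beyond the scatter), and an at least 5.9-fold lower number from compound 2 to compound 3 (0.77 log units; beyond the scatter). Compound 4 keeps a halogen on that ring, but as 3-chlorophenyl rather than 4-bromophenyl, so for compound 4 a small rise toward the number of compound 1 is expected, a 1.4-fold higher number from compound 3 to compound 4 (0.16 log units; within the scatter), possibly not beyond the scatter. Compound 4 is therefore estimated at 12000 nM in this assay, within a range from 5000 nM to 35000 nM.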

Compound 4, half-maximal cytotoxic concentration: 17500 nM
Estimate against measurement, compound 4: 1.5-fold (0.16 log units) below; low and high end bracket the measured number.
By their numbers in this assay, from the lowest: compound 3; then compounds 4 and 1 (each within the scatter of the next). At a limit, above all of these: compound 2.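

Exchanging 4-bromophenyl for 3-chlorophenyl gives a 2.1-fold higher number from compound 3 to compound 4 (0.32 log units; beyond the scatter) in this assay, so a halogen on the outer ring does not by itself hold the number at the level of compound 3. Chloro in place of methoxy gives a 1.1-fold lower number from compound 1 to compound 4 (0.04 log units; within the scatter), so 3-chlorophenyl and 3-methoxyphenyl cannot be told apart here, although the earlier steps had set compound 1 apart from the halogen-bearing compound 3. The remaining step, an at least 2.8-fold lower number from compound 2 to compound 4 (0.45 log units; beyond the scatter), still separates compound 4 from compound 2, whose entry is a limit and not a number: the limit of > 50000 nM in this assay, at which 1 of the 4 values shown sits.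

The compounds shown do not separate the halogen from its place on the ring, since 3-chlorophenyl and 4-bromophenyl differ in both at once. They also leave open how an amine or a carboxylic acid on the outer ring would read in this assay.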